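The source may report more compounds than this note shows. Statements on the series, on what has been measured and on what is new or still open speak of the compounds shown alone.

Measured in a functional assay on RPMI-7951 cells (Homo sapiens) for cytotoxicity; a higher number here means that more compound is needed for the effect, a lower number that less compound is needed:
- compound 1 `Oc1ccc2nc(-c3ccccc3)cc(O)c2c1`: 3.92 ug/mL
- compound 2 `Oc1cc(-c2ccccc2)nc2ccc(Cl)cc12`: 0.64 ug/mL
- compound 3 `Oc1cc(-c2ccccc2)nc2cc(F)ccc12`: 0.37 ug/mL

Compound 2, at 0.64 ug/mL, lies within the scatter of compound 3, at 0.37 ug/mL. Compound 1, at 3.92 ug/mL, stands clearly apart from compound 2, beyond the scatter. The next compound to read is compound 4 `COc1ccc2nc(-c3ccccc3)cc(O)c2c1`, which has methoxy in place of chloro on an aromatic carbon of compound 2: methoxy in place of chloro on an aromatic carbon.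

Among the measured compounds shown here, only one measured step bears directly on this change: a 6.1-fold lower number from compound 1 to compound 2 (0.79 log units; beyond the scatter), with chloro in place of hydroxy on the same aromatic carbon. For the measured compounds named here, compound 3 differs from compound 2 in more than one place, so it gives no clean step here. Going by the values given here, no compound measured so far carries methoxy, which leaves the comparison indirect. Compound 4 resembles compound 1 in having oxygen attached at that carbon, so part of the step seen with compound 1, 3.92 ug/mL, may be reversed. A modest move to a higher number is therefore expected, smaller than the measured step. The estimated step is a 2.5-fold higher number from compound 2 to compound 4 (0.40 log units; beyond the scatter), and no-change remains within reach. For compound 4 the expected value in this assay is 1.6 ug/mL, with an estimated range of 0.5 ug/mL to 5 ug/mL.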

Compound 4, half-maximal effective concentration: 0.36 ug/mL
Estimate against measurement, compound 4: 4.4-fold (0.65 log units) above, outside the stated range (below it).
By their numbers in this assay, from the lowest: compounds 4, 3 and 2 (each within the scatter of the next); then compound 1.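

Across this assay, the exchange of chloro for methoxy on this aromatic carbon reads as a 1.8-fold lower number from compound 2 to compound 4 (0.25 log units; within the scatter), so the two groups cannot be told apart here, although methoxy brings an oxygen to the same carbon and one more heavy atom. Attached oxygen alone therefore does not set compound 1 apart from compound 2: methyl in place of hydrogen on that oxygen gives an 11-fold lower number from compound 1 to compound 4 (1.04 log units; beyond the scatter), and the chloro compound shows the matching step, a 6.1-fold lower number from compound 1 to compound 2 (0.79 log units; beyond the scatter), so among these three compounds only the free hydroxy stands apart at this carbon. Nothing at hand gives a measured reason for this difference between the free hydroxy and the other two groups.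

Still open, as far as these compounds go, is whether the response stays this flat with an amine, a carboxylic acid or a longer alkoxy chain on the same carbon, or whether it is specific to chloro and methoxy. Compound 3 differs from compound 2 and from compound 4 in more than one place, so the contribution of its fluoro on the shared core remains unresolved by the compounds in hand.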